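Dropping One Trifluoromethyl Group: Expected Loss of Potency

A few compounds are considered here, and "the series" means these few. Any claim that something is new, unique, unknown or untested is made for them only; others in the source may bear on it.

Within the data shown here, compound 2 `CN(C(=O)NC(=O)c1ccc(F)c(F)c1)c1nc(C(F)(F)F)c(C(=O)N/N=C/c2cc(C(F)(F)F)cc(C(F)(F)F)c2)s1` gives 2.61 ug/mL in a functional assay on MCF7 cells (Homo sapiens) for inhibition, read by MTT assay, with a stated time of 72 h (on this read-out lower numbers stand for stronger inhibition and higher numbers for weaker inhibition), the lowest of the two numbers measured so far, while compound 1 `CN(C(=O)NC(=O)c1c(F)cccc1F)c1nc(C(F)(F)F)c(C(=O)N/N=C/c2cccc(C(F)(F)F)c2)s1` gives 21.8 ug/mL, a gap beyond the usual scatter. Compound 3 `CN(C(=O)NC(=O)c1ccc(F)c(F)c1)c1nc(C(F)(F)F)c(C(=O)N/N=C/c2cccc(C(F)(F)F)c2)s1` has not yet been measured. It differs from compound 2 by hydrogen in place of trifluoromethyl on an aromatic carbon. Among the measured compounds shown here, compound 1 also carries a single trifluoromethyl on that ring, but its other aromatic ring bears fluorine in a different pattern, so no single-change step is known. A weakening step is expected from compound 2 to compound 3, a 3.1-fold higher number from compound 2 to compound 3 (0.49 log units; beyond the scatter). Compound 3 is estimated at 8 ug/mL, with a likely range from 3 ug/mL to 25 ug/mL.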

Compound 3, half-maximal inhibitory concentration: 4.15 ug/mL
The estimate for compound 3 lay 1.9-fold (0.29 log units) above the measured number, within the range that was stated.
By their numbers in this assay, from the lowest: compounds 2 and 3 (each within the scatter of the next); then compound 1.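

In this assay, hydrogen in place of trifluoromethyl on this aromatic carbon gives a step within the usual scatter (a 1.6-fold higher number from compound 2 to compound 3 (0.20 log units; within the scatter)), so the second trifluoromethyl group is not needed to keep this level of inhibition. The clear step comes instead from 3,4-difluorophenyl in place of 2,6-difluorophenyl on a carbonyl carbon (a 5.3-fold lower number from compound 1 to compound 3 (0.72 log units; beyond the scatter)). Nothing given here explains either step. From the compounds shown here alone, whether a methoxy group or an amine on this aromatic carbon would also fit remains open. So does whether a single fluorine on the carbonyl-bound ring would do as well.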